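Compound 3 and its mirror image, compound 4

The source may report more compounds than this note shows. Statements on the series, on what has been measured and on what is new or still open speak of the compounds shown alone.

Measured in an ADME assay on MDCK cells (Canis lupus familiaris) for permeability, read by LC-MS, with a stated time of 90 min, tested at 2 uM; on this read-out higher numbers stand for higher permeability and lower numbers for lower permeability:
- compound 1 `COC(c1cc(Cl)c2c(c1Cl)C(=O)N(Cc1c(C)cc(C)[nH]c1=O)CC2)C1CCOCC1`: 13.3 10^-6 cm/s; 16.5 10^-6 cm/s (2 entries)
- compound 2 `Cc1cc(C)c(CN2CCc3c(Cl)cc([C@H](CO)[C@H]4CCCO4)c(Cl)c3C2=O)c(=O)[nH]1`: 4.1 10^-6 cm/s
- compound 3 `Cc1cc(C)c(CN2CCc3c(Cl)cc([C@H](CO)[C@@H]4CCCO4)c(Cl)c3C2=O)c(=O)[nH]1`: 14.6 10^-6 cm/s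

Compound 3 gives 14.6 10^-6 cm/s, the higher number of its pair with compound 2, and it falls within the range of the repeat entries for compound 1 (the several entries of compound 1 in this assay, 13.3 10^-6 cm/s; 16.5 10^-6 cm/s (2 entries)). Compound 4 `Cc1cc(C)c(CN2CCc3c(Cl)cc([C@@H](CO)[C@H]4CCCO4)c(Cl)c3C2=O)c(=O)[nH]1` comes next: the two compounds have the same atoms and bonds and differ only in configuration as drawn: 2 of 2 stereo elements differ (all stereocentres are inverted: mirror images); a stereocentre at a saturated chain carbon is drawn R in compound 3 and S in compound 4; a stereocentre at a saturated ring carbon is drawn S in compound 3 and R in compound 4. Within the data shown here, the one measured step that bears on this is a 3.6-fold higher number from compound 2 to compound 3 (0.55 log units; beyond the scatter), and it comes with the fact that compounds 2 and 3 differ only in the configuration as drawn. That pair differs at only one stereocentre and is not a mirror-image pair, so its size need not carry over. Compound 4 is the mirror image of compound 3, so no step beyond the scatter is expected in this assay. The expected change is a 1.1-fold lower number from compound 3 to compound 4 (0.05 log units; within the scatter). For compound 4, the estimate is 13 10^-6 cm/s, with an expected range from 7 10^-6 cm/s to 23 10^-6 cm/s.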

Compound 4, apparent permeability: 8.5 10^-6 cm/s
Compound 4: middle estimate off by 1.5-fold (0.18 log units), on the high side; low and high end bracket the measured number.
By their numbers in this assay, from the lowest: compound 2; then compounds 4 and 3 (each within the scatter of the next).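

In this assay, inverting both stereocentres gives a 1.7-fold lower number from compound 3 to compound 4 (0.23 log units; within the scatter), so this mirror-image pair stays within the scatter. Changing only the chain stereocentre gives a 2.1-fold higher number from compound 2 to compound 4 (0.32 log units; beyond the scatter), which leaves compound 2 below both of the others through the drawn configuration alone: the fact that compounds 2 and 4 differ only in the configuration as drawn. Three stereoisomers cannot show whether this gap is general. From the compounds shown here alone, it remains open whether the same gap would appear if an amine or a carboxylic acid took the place of the hydroxyl at the chain stereocentre.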